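This account rests on a few compounds, and the source may have more. Where it says the series, first, only, none or still open, it means among the compounds named here.

Compound 3 `CN1CCC(N(C)C(=O)C2CN(S(=O)(=O)c3ccc4ccccc4c3)c3ccccc32)CC1` is one of three compounds with a number in a functional assay on CHO cells for antagonist activity at 5-hydroxytryptamine receptor 6 (Homo sapiens), read by FLIPR; on this read-out lower numbers stand for stronger inhibition and higher numbers for weaker inhibition; in this assay compound 3 gives 25.1 nM. Compound 1 `COc1ccc(S(=O)(=O)N2CC(C(=O)NC3CCN(C)CC3)c3ccccc32)c2ccccc12` gives 25.1 nM in this assay, level with compound 3 at the digits shown, so the two stand together at the lowest numbers of the set. Within the data shown here, compound 2 `COc1ccc(S(=O)(=O)N2CC(C(=O)N3CC(CN)C3)c3ccccc32)c2ccccc12` gives 79.4 nM in this assay, and the only measured single-point step, a 3.2-fold higher number from compound 1 to compound 2 (0.50 log units; beyond the scatter), concerns the group on the carbonyl carbon. Compound 4 `COc1cc(C)c(S(=O)(=O)N2CC(C(=O)N(C)C3CCN(C)CC3)c3ccccc32)c(C)c1C` is not yet measured. It differs from compound 3 at a different place: 4-methoxy-2,3,6-trimethylphenyl in place of naphthalen-2-yl on a sulfonyl sulfur. Among the measured compounds shown here, no measured step touches the group on the sulfonyl sulfur, so the single measured step gives no direct guide for this change, and the expectation rests on compound 3 alone. The step from compound 3 to compound 4 is expected to be small, a 1.6-fold higher number from compound 3 to compound 4 (0.20 log units; within the scatter), with a wide range in either direction. Compound 4 is therefore estimated at 40 nM in this assay, between 10 nM and 160 nM.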

Compound 4, inhibition constant: 100 nM
For compound 4 the middle estimate is 2.5-fold (0.40 log units) below the measured one; the measured number falls inside the stated range.
By their numbers in this assay, from the lowest: compounds 1 and 3 (each within the scatter of the next); then compounds 2 and 4 (each within the scatter of the next).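

Among these compounds, the change on the sulfonyl sulfur gives a 4.0-fold higher number from compound 3 to compound 4 (0.60 log units; beyond the scatter) in this assay and is the first measured step at this place, so the group held there does shift the number. Replacing naphthalen-2-yl, with its two six-membered aromatic rings, by 4-methoxy-2,3,6-trimethylphenyl, with one such ring and one hydrogen-bond acceptor, weakens inhibition only modestly and does not abolish it. Nothing available here bears on why the number moves, so the step stands as an observation only.

The loss of the second ring and the arrival of the methoxy and methyl groups come together in this one step, and the compounds shown do not separate them. A plain phenyl or a 4-methoxyphenyl group on the sulfonyl sulfur would tell these contributions apart.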